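A few compounds are considered here, and "the series" means these few. Any claim that something is new, unique, unknown or untested is made for them only; others in the source may bear on it.

In an ADME assay on HEK-293T cells (Homo sapiens) for inhibition, read by CCK-8 assay, with a stated time of 48 h, tested at 20 uM (on this read-out higher numbers stand for more inhibition of growth at the one concentration tested and lower numbers for less inhibition of growth), compound 3 (`COc1ccc(Cc2nnc(NC(=O)/C(C#N)=C/c3ccccc3OS(=O)(=O)c3ccc(OC)cc3)s2)cc1`) gives 30%, within the scatter of the two other measured members, compound 1 (`N#C/C(=C\c1ccccc1OS(=O)(=O)c1ccc([N+](=O)[O-])cc1)C(=O)Nc1nnc(-c2cccs2)s1`) at 33% and compound 2 (`COc1ccc(Cc2nnc(NC(=O)/C(C#N)=C/c3ccccc3OS(=O)(=O)c3ccc(C)cc3)s2)cc1`) at 21%. Compound 4 (`COc1ccc(Cc2nnc(NC(=O)/C(C#N)=C/c3ccccc3OS(=O)(=O)c3ccc([N+](=O)[O-])cc3)s2)cc1`) differs from compound 3 by nitro in place of methoxy on an aromatic carbon, para to a large group. Among the measured compounds shown here, the only measured step on that carbon, a number 9 percentage points higher from compound 2 to compound 3 (within the scatter), stayed within the scatter. Compound 1, at 33%, already carries the (4-nitrophenyl)sulfonyl group, but with a different remainder. No change beyond the scatter is therefore expected, and the estimated step is a number 1 percentage points higher from compound 3 to compound 4 (within the scatter). For compound 4 the expected value is 31%, with an estimated range of 20% to 43%.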

Compound 4, percent growth inhibition at one concentration: 17%
Compound 4: middle estimate off by 14 percentage points, on the high side; measured number below the stated range.
By their numbers in this assay, from the lowest: compounds 4, 2, 3 and 1 (each within the scatter of the next, the first and the last beyond it).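

Nitro in place of methoxy gives a number 13 percentage points lower from compound 3 to compound 4 (beyond the scatter) in this assay, the first step at this aromatic carbon to leave the scatter, whereas nitro in place of methyl gives a number 4 percentage points lower from compound 2 to compound 4 (within the scatter). With the (4-nitrophenyl)sulfonyl group held constant, 4-methoxybenzyl in place of thiophen-2-yl gives a number 16 percentage points lower from compound 1 to compound 4 (beyond the scatter), so the change elsewhere in the molecule also moves this read-out. No measurement here accounts for either step.

Going by these compounds, whether an amine or a carboxylic acid at this aromatic carbon would separate from methoxy remains open. So does whether the methoxy-to-nitro step recurs with thiophen-2-yl in place of 4-methoxybenzyl.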